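A few compounds are considered here, and "the series" means these few. Any claim that something is new, unique, unknown or untested is made for them only; others in the source may bear on it.

Measured compounds in a functional assay on MCF7 cells (Homo sapiens) for antiproliferative activity, read by sulforhodamine B assay, with a stated time of 48 h; a higher number here means a weaker inhibitor, a lower number a stronger inhibitor:
compound 1 `CCCN1CCN(c2ccc(S(=O)(=O)Oc3ccc(C)cc3C)cc2)C1=O` gives 1500 nM
compound 2 `CCCN1CCN(c2ccc(S(=O)(=O)Oc3cccc(OC)c3)cc2)C1=O` gives 6300 nM

Compound 2 stands at the higher of the two numbers in this assay; its nearest neighbour is compound 1, and the step of a 4.2-fold higher number from compound 1 to compound 2 (0.62 log units; beyond the scatter) separates them, beyond the scatter. Compound 3 `CCCN1CCN(c2ccc(S(=O)(=O)Oc3ccc(F)cc3)cc2)C1=O` is not yet measured. Its difference from compound 2 is 4-fluorophenyl in place of 3-methoxyphenyl on an oxygen, on the oxygen that is bound to the sulfonyl sulfur. For the measured compounds named here, the only measured step that bears on this position is the step from compound 1 to compound 2, which swapped the aryl group on the same oxygen and gave a modest rise in the number. A second aryl swap at the same oxygen may therefore move the number by a comparable amount; the direction is not fixed by a single step. The expected step from compound 2 to compound 3 is a 2.1-fold lower number from compound 2 to compound 3 (0.32 log units; beyond the scatter). Compound 3 is estimated at 3000 nM, with a range from 1000 nM to 9000 nM.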

Compound 3, half-maximal inhibitory concentration: 33000 nM
Beside the measured number, compound 3's estimate is 11-fold (1.04 log units) below it, and the stated range ends below it.
By their numbers in this assay, from the lowest: compound 1; then compound 2; then compound 3.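

The aryl group on the oxygen bound to the sulfonyl sulfur now shows a wider span in this assay than the first step alone revealed: 4-fluorophenyl in place of 3-methoxyphenyl gives a further rise (a 5.2-fold higher number from compound 2 to compound 3 (0.72 log units; beyond the scatter)), and 4-fluorophenyl in place of 2,4-dimethylphenyl gives a large one (a 22-fold higher number from compound 1 to compound 3 (1.34 log units; beyond the scatter)). With the rest of the structure held constant, this one position therefore orders all three compounds, with every step beyond the scatter. No supporting measurement on hand accounts for this order.

The three aryl groups differ in both the kind and the placement of their substituents, so the two factors cannot be separated here. Where phenyl, 4-methoxyphenyl or 3-fluorophenyl would fall in this order remains open.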